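From ethyl to sec-butyl in a growth-inhibition series

This account rests on a few compounds, and the source may have more. Where it says the series, first, only, none or still open, it means among the compounds named here.

Measured so far:
compound 1 `CCOC(=O)C#CC(O/C=C/C(=O)OCC)C(C)C`: 2800 nM
compound 2 `CCC(C#CC(=O)OC)O/C=C/C(=O)OC`: 540 nM
compound 3 `CCOC(=O)C#CC(C[C@@H](C)CCC=C(C)C)O/C=C/C(=O)OCC`: 2600 nM

All three compounds were tested in a functional assay on SW1573 cells (Homo sapiens) for antiproliferative activity, read by sulforhodamine B assay, with a stated time of 48 h; a higher number here means a weaker inhibitor of growth, a lower number a stronger inhibitor of growth. Compound 2 holds the lowest of the three numbers, at 540 nM. Compound 1 at 2800 nM and compound 3 at 2600 nM both lie above it, beyond the scatter, although each differs from compound 2 in more than one place.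

Compound 4 `CCC(C)C(C#CC(=O)OC)O/C=C/C(=O)OC` has not yet been measured. It departs from compound 2 in a single place: ethyl in place of hydrogen on a saturated chain carbon bound to two saturated chain carbons. This is ethyl in place of hydrogen on a saturated chain carbon bound to two saturated chain carbons, and cut one bond further out, the same difference reads ethyl to sec-butyl.

Going by the values given here, no measured pair isolates a change of this kind, so the expectation rests on thin ground. In this assay, a moderate rise in the number is expected, near the edge of the scatter, which would mean weaker growth inhibition. The estimated step is a 2.2-fold higher number from compound 2 to compound 4 (0.35 log units; beyond the scatter). For compound 4 the expected value is 1200 nM, with an estimated range of 450 nM to 3000 nM.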

Compound 4, concentration for 50% growth inhibition: 910 nM
For compound 4 the middle estimate is 1.3-fold (0.12 log units) above the measured one; the range from low to high includes it.
By their numbers in this assay, from the lowest: compounds 2 and 4 (each within the scatter of the next); then compounds 3 and 1 (each within the scatter of the next).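

Going by these compounds alone, compound 2 and compound 4 form the first pair that differs in one place, so the change can be read on its own for the first time. In this assay, ethyl in place of hydrogen on a saturated chain carbon bound to two saturated chain carbons gives a 1.7-fold higher number from compound 2 to compound 4 (0.23 log units; within the scatter), and the two compounds cannot be told apart at this level of resolution. The earlier compounds shown here could not show this, since compound 1 and compound 3 each differ from compound 2 in more than one place, and the present result shows that this position can carry the larger sec-butyl group without a step beyond the scatter. Nothing available explains why the two compounds read alike.

The pair leaves open whether a longer chain, an amine, a carboxylic acid or a phenyl ring at this place would also stay within the scatter of compound 2. It also leaves open what the ethyl esters of compound 1 and compound 3 contribute on their own, since no pair shown isolates a change from methyl ester to ethyl ester.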